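Shrinking the Ring on a Weakly Cytotoxic Amide

A few compounds are considered here, and "the series" means these few. Any claim that something is new, unique, unknown or untested is made for them only; others in the source may bear on it.

Measured compounds:
compound 1 `O=C(Nc1cc(C(F)(F)F)ccc1N1CCCCC1)c1ccccc1`: "not active" (no number reported)
compound 2 `CCN(CC)c1ccc(C(F)(F)F)cc1NC(=O)c1cccnc1`: 63200 nM
compound 3 `O=C(Nc1cc(C(F)(F)F)ccc1NC1CCCCC1)c1ccccc1`: "not active" (no number reported)

In a functional assay on NALM-6 cells (Homo sapiens) for cytotoxicity, read by MTT assay, with a stated time of 48 h (on this read-out higher numbers stand for weaker inhibition and lower numbers for stronger inhibition), compound 1 is reported only as "not active" (no number reported), without a number. Compound 3 is likewise reported without a number in this assay. Among the measured compounds shown here, the one numeric value in the set belongs to compound 2, which gives 63200 nM in this assay; this is a weak result in its own right. Compound 1 therefore has no single number to stand on, and compound 3 shares this position.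

Compound 4 `O=C(Nc1cc(C(F)(F)F)ccc1N1CCCC1)c1ccccc1` differs from compound 1 by a single change: pyrrolidin-1-yl in place of piperidin-1-yl on an aromatic carbon. For the measured compounds named here, no measured pair in the set reports such a step, so the size of the step in this assay is unknown. With compound 1 reported as inactive, and the only numeric entry, compound 2, weak, no movement beyond the usual scatter of this assay is expected from this change. Compound 4 is expected to give about 80000 nM in this assay, within a range from 25000 nM to 250000 nM, and it is considered likely that only a limit rather than a number will be reported.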

Compound 4, half-maximal inhibitory concentration: "not active" (no number reported)
The entry for compound 4 holds no number, and the estimate cannot be compared.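

Compound 4, like compound 1, is reported without a number, so no step can be read between them. Nothing in the data shown bears on this result. The compounds shown leave open whether pyrrolidin-1-yl in place of piperidin-1-yl changes cytotoxicity at all.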